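Working notes: from compound 1 to compound 3

A few compounds are considered here, and "the series" means these few. Any claim that something is new, unique, unknown or untested is made for them only; others in the source may bear on it.

- compound 1 `Oc1ccc(CN(Cc2ccccc2C(F)(F)F)Cc2ccc(O)c3ncccc23)c2cccnc12` gives 46 nM
- compound 2 `Oc1ccc(CN(Cc2cc(C(F)(F)F)cc(C(F)(F)F)c2)Cc2ccc(O)c3ncccc23)c2cccnc12` gives 9 nM

In a functional assay on A549 cells (Homo sapiens) for cytotoxicity, read by MTT assay (on this read-out lower numbers stand for stronger inhibition and higher numbers for weaker inhibition), compound 1 stands highest of the two measured compounds at 46 nM and compound 2 lies lower at 9 nM with a gap beyond the usual scatter. Among the compounds with values here, the structural change to compound 3 `Oc1ccc(CN(Cc2cccc(I)c2)Cc2ccc(O)c3ncccc23)c2cccnc12` is 3-iodophenyl in place of 2-(trifluoromethyl)phenyl on a saturated chain carbon bound to an amine nitrogen and no measured step covers it. Only the span of the two values guides the expectation, which is a small move toward lower numbers in this assay and not clearly beyond the scatter. The expected step is a 1.8-fold lower number from compound 1 to compound 3 (0.26 log units; within the scatter) on this limited evidence. Compound 3 is estimated at 25 nM within an expected range of 8 nM to 80 nM for now.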

Compound 3, half-maximal inhibitory concentration: 350 nM
The estimate for compound 3 lay 14-fold (1.15 log units) below the measured number; the measured number lies above the stated range.
By their numbers in this assay, from the lowest: compound 2; then compound 1; then compound 3.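

In this assay, within the data shown here, 3-iodophenyl in place of 2-(trifluoromethyl)phenyl gives a 7.6-fold higher number from compound 1 to compound 3 (0.88 log units; beyond the scatter), a step beyond the scatter and the first measured step. The aryl group on this saturated chain carbon bound to an amine nitrogen is therefore not freely interchangeable. Nothing at hand bears on the reason for this step.

Going by these compounds, whether the step follows the arrival of iodine or the departure of trifluoromethyl stays open, as this single change cannot separate the two. A plain phenyl or a chlorophenyl group at this place would help to separate them.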